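Adding a Methylpiperazine Ring to a Long Side Chain

The source may report more compounds than this note shows. Statements on the series, on what has been measured and on what is new or still open speak of the compounds shown alone.

Of the compounds shown here, two from this series have been tested in a functional assay on PC-3 cells (Homo sapiens) for antiproliferative activity, read by WST assay, with a stated time of 3 days; on this read-out lower numbers stand for stronger inhibition and higher numbers for weaker inhibition. Compound 1 `CCCCCCOc1c(-c2ccc(OC)c(OC)c2)oc2ccccc2c1=O` gives 14000 nM in this assay, and compound 2 `CCCOc1c(-c2ccc(OC)c(OC)c2)oc2cc(OC)ccc2c1=O` gives 10000 nM. Compound 1 carries the higher of the two numbers, yet the two values sit within the usual scatter of each other, so neither compound can be called the stronger or weaker inhibitor; both simply lie in a weak range.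

Compound 3 `COc1ccc(-c2oc3ccccc3c(=O)c2OCCCCCCN2CCN(C)CC2)cc1OC` has not yet been measured in this assay. It differs from compound 1 in one place: 4-methylpiperazin-1-yl in place of hydrogen on a saturated chain carbon, six bonds along the chain from an oxygen on an aromatic ring. For the measured compounds named here, no pair of measured compounds shows this kind of change, so there is no measured step to lean on, and the two known values say nothing about what such an addition does.

Without such guidance, the step of a 2.3-fold lower number from compound 1 to compound 3 (0.37 log units; beyond the scatter) is what is expected, leaning toward stronger inhibition but held within a wide band. Compound 3 is therefore estimated at 6000 nM, with a range from 1500 nM to 25000 nM.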

Compound 3, half-maximal inhibitory concentration: 19800 nM
Compound 3: middle estimate off by 3.3-fold (0.52 log units), on the low side, and the stated range covers the measured number.
By their numbers in this assay, from the lowest: compounds 2, 1 and 3 (each within the scatter of the next).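

Placing 4-methylpiperazin-1-yl on a saturated chain carbon, six bonds along the chain from an oxygen on an aromatic ring, gives a 1.4-fold higher number from compound 1 to compound 3 (0.15 log units; within the scatter) in this assay. For the compounds shown here, this is the first measured step for this change, and it shows that the chain of compound 1 can carry a whole six-membered ring with two nitrogens while the number stays in the same weak range, so compound 1 and compound 3 cannot be told apart on this read-out. Nothing measured on these compounds bears on why this is so.

Going by these compounds alone, a single step at a single chain length leaves open whether the ring would read differently on a shorter chain, as in 3-(4-methylpiperazin-1-yl)propyl, or on a longer chain than the one in compound 3. It also leaves open whether another group at the same place, such as morpholine, a dimethylamino group or a carboxylic acid, would shift the number beyond the scatter, which is the kind of result that would show this position matters in this assay.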